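Removing the linker before the isothiocyanate in compound 3

The source may report more compounds than this note shows. Statements on the series, on what has been measured and on what is new or still open speak of the compounds shown alone.

Compound 3 `CN(C)C(=O)c1cc2cnc(Nc3ccc(NC(=O)CCCCN=C=S)cc3)nc2n1C1CCCC1` stands second highest of the three numbers in a functional assay on A549 cells (Homo sapiens) for inhibition, read by CCK-8 assay, with a stated time of 72 h, tested at 1 uM; a lower number here means a weaker effect, a higher number a stronger effect of the compound at the concentration tested: compound 3 gives 38.2%. Compound 1 `CN(C)C(=O)c1cc2cnc(Nc3ccc(S(=O)(=O)NCCCN=C=S)cc3)nc2n1C1CCCC1` gives 58.9% in this assay, and compound 2 `CN(C)C(=O)c1cc2cnc(Nc3ccc(C(=O)NCCCCCN=C=S)cc3)nc2n1C1CCCC1` gives 29.3%. The step of a number 8.9 percentage points higher from compound 2 to compound 3 (within the scatter) lies within the scatter, whereas a number 20.7 percentage points lower from compound 1 to compound 3 (beyond the scatter) lies beyond it.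

Compound 4 `CN(C)C(=O)c1cc2cnc(Nc3ccc(N=C=S)cc3)nc2n1C1CCCC1` differs from compound 3 in one place: a group of 3 heavy atoms (1 carbon, 1 nitrogen, 1 sulfur; no ring) in place of a group of 10 heavy atoms (6 carbon, 2 nitrogen, 1 oxygen, 1 sulfur; no ring), on an aromatic carbon. The measured steps that touch this position all swap one linker for another of roughly equal size: a number 29.6 percentage points lower from compound 1 to compound 2 (beyond the scatter) and a number 20.7 percentage points lower from compound 1 to compound 3 (beyond the scatter) both moved the number beyond the scatter, while a number 8.9 percentage points higher from compound 2 to compound 3 (within the scatter) stayed within it. Going by the values given here, no measured step removes the linker altogether, so nothing among the three compounds shows directly what the bare group on the ring does. The two linker swaps that changed the number show that this part of the molecule matters, so a step of modest size in either direction cannot be excluded, and the estimate therefore sits near the middle of the three measured values with a wide range. Compound 4 is expected to give 40%, from 15% to 65%, which means an expected step of a number 1.8 percentage points higher from compound 3 to compound 4 (within the scatter).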

Compound 4, a percentage reported as inhibition, at one concentration (the size of the read-out at that concentration, not a potency): 44.4%
Estimate against measurement, compound 4: 4.4 percentage points below; measured number inside the range.
By their numbers in this assay, from the lowest: compounds 2, 3 and 4 (each within the scatter of the next, the first and the last beyond it); then compound 1.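

In this assay, compound 4 shows that the isothiocyanate can stand directly on the aromatic carbon without the chain and still give a number that cannot be told apart from that of the amide-linked compound 3, with a number 6.2 percentage points higher from compound 3 to compound 4 (within the scatter). Measured against the other two linked compounds, the bare group falls on different sides, with a number 15.1 percentage points higher from compound 2 to compound 4 (beyond the scatter) and a number 14.5 percentage points lower from compound 1 to compound 4 (beyond the scatter), so a linker at this position does not act in one direction: among these compounds the sulfonamide-linked one gives the highest number and the longer amide-linked one the lowest, while the shorter amide-linked compound 3 goes with neither trend. Nothing in the available information accounts for these differences.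

The linked compounds differ in both the connecting group and the chain length, so the compounds shown leave open which of the two sets the number, and a sulfonamide with a longer chain would help to separate them. All four also carry the isothiocyanate, which leaves open what an amine or an acetamide in its place would give.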